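The compounds below may be only part of what the source reports. "The series", "measured", "known", "first", "only" and "open" are said of these compounds alone.

Measured so far:
Compound 1, `COc1cc(SC)nc(NC(=S)NC(=O)c2c(-c3ccc(Cl)cc3Cl)noc2C)n1`: 40.9%
Compound 2, `Cc1onc(-c2ccc(Cl)cc2Cl)c1C(=O)/N=c1/nc2nc(Cl)cc(C)n2s1`: 55.6%

In a functional assay on the whole organism (strain L.) for inhibition, with Echinochloa crus-galli as the target, with a stated time of 72 h, tested at 100 mg/L (on this read-out higher numbers stand for more inhibition of growth at the one concentration tested and lower numbers for less inhibition of growth), compound 1 gives 40.9%, the lower of the two numbers; compound 2 gives 55.6%, and the gap between them lies beyond the usual scatter. Compound 3 `COc1cc(OC)nc(NC(=S)NC(=O)c2c(-c3ccc(Cl)cc3Cl)noc2C)n1` has not been measured; it differs from compound 1 by methoxy in place of methylsulfanyl on an aromatic carbon. Among the compounds with values here, no measured pair shows this exchange, so its size is unknown; a step of no more than the scatter, in either direction, is expected, giving a number 2.9 percentage points lower from compound 1 to compound 3 (within the scatter). Compound 3 is accordingly estimated at 38%, in the range 20% to 58%.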

Compound 3, percent growth inhibition at one concentration: 60.9%
Compound 3: middle estimate off by 22.9 percentage points, on the low side, and the stated range ends below it.
By their numbers in this assay, from the lowest: compound 1; then compounds 2 and 3 (each within the scatter of the next).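

The exchange of methylsulfanyl for methoxy on this aromatic carbon, next to the ring nitrogen, gives a number 20 percentage points higher from compound 1 to compound 3 (beyond the scatter) in this assay. This place therefore matters for growth inhibition, even though the two groups count the same heavy atoms and hydrogen-bond acceptors, and the 4,6-dimethoxypyrimidin-2-yl compound 3 is clearly ahead of compound 1. Nothing available explains this step. The compounds shown leave open how an amine, a chlorine or an ethoxy group would fare on the same carbon. They also leave open whether this exchange would carry the same weight on another core.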